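This account rests on a few compounds, and the source may have more. Where it says the series, first, only, none or still open, it means among the compounds named here.

Series notes, liver clearance read-out.

Compound 1 `CCOc1cc([C@](O)(CCN(C)C)[C@H](c2cccc(C)c2)c2cc3cc(Br)ccc3nc2OC)cc(OC)n1` gives 4.4 uL/min in an ADME assay on microsomes from liver (Homo sapiens) for metabolic stability; on this read-out lower numbers stand for slow clearance and higher numbers for fast clearance. Compound 2 `CCOc1cc([C@](O)(CCN(C)C)[C@@H](c2cc3cc(Br)ccc3nc2OC)c2ccnc(OC)c2OC)cc(OC)n1` gives 3.8 uL/min, and the step of a 1.2-fold lower number from compound 1 to compound 2 (0.06 log units; within the scatter) is within the scatter. Compound 3 `CCCOc1cc([C@](O)(CCN(C)C)[C@@H](c2cc3cc(Br)ccc3nc2OC)c2ccnc(OC)c2OC)cc(OC)n1` gives 8.2 uL/min; the step of a 2.2-fold higher number from compound 2 to compound 3 (0.33 log units; beyond the scatter) is a modest one beyond the scatter. Compound 3 therefore has the highest number of the three, separated from compound 1 by a gap within the scatter and from compound 2 by a gap beyond it.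

Compound 4 `COc1cc([C@](O)(CCN(C)C)[C@@H](c2cc3cc(Br)ccc3nc2OC)c2ccnc(OC)c2OC)cc(OC(F)F)n1` is the next member and has not yet been measured. It differs from compound 3 in one place: difluoromethyl in place of propyl on an oxygen on an aromatic ring. Going by the values given here, the only measured step that bears on this position is the one from compound 2 to compound 3, where the chain on the same aromatic oxygen was lengthened by one carbon and the clearance number rose modestly. Compound 4 removes that chain and places difluoromethyl on the oxygen instead. With one relevant step of modest size, the expectation is that the number for compound 4 falls back toward the range of compound 1 and compound 2 rather than rising further, estimated as a 1.8-fold lower number from compound 3 to compound 4 (0.26 log units; within the scatter). The estimate for compound 4 in this assay is 4.5 uL/min, expected between 2.2 uL/min and 9 uL/min.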

Compound 4, intrinsic clearance in a liver preparation (reported as CLH), per the amount of preparation that the assay uses: 2.1 uL/min
Beside the measured number, compound 4's estimate is 2.1-fold (0.33 log units) above it; measured number below the stated range.
By their numbers in this assay, from the lowest: compounds 4, 2, 1 and 3 (each within the scatter of the next, the first and the last beyond it).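

Compound 3 had shown that lengthening the chain on this aromatic oxygen from ethyl to propyl could raise the number in this assay, with a 2.2-fold higher number from compound 2 to compound 3 (0.33 log units; beyond the scatter); the new result shows that the number at this position can also move down, with difluoromethyl in place of propyl giving a 3.9-fold lower number from compound 3 to compound 4 (0.59 log units; beyond the scatter), although both groups have the same count of heavy atoms. Against ethyl, difluoromethyl gives a 1.8-fold lower number from compound 2 to compound 4 (0.26 log units; within the scatter), so these two groups on this oxygen cannot be told apart in this read-out, and among the three groups compared here only propyl stands apart from both. Nothing at hand gives a measured reason for these differences.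

With only three groups compared on this oxygen, the compounds shown leave open whether a longer chain such as butyl would continue the rise seen with propyl, and whether trifluoromethyl or a cyclopropyl group would sit with ethyl and difluoromethyl or with propyl. They also leave open whether the same swap would give a similar step with the 3-methylphenyl group of compound 1 in place of the 2,3-dimethoxypyridin-4-yl group.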